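Chloro for Fluoro on a Shared Benzylidene Piperidinone Core

A few compounds are considered here, and "the series" means these few. Any claim that something is new, unique, unknown or untested is made for them only; others in the source may bear on it.

Measured compounds:
Compound 1, `COc1cc(/C=C2\CN(C)C/C(=C\c3ccc(F)cc3)C2=O)cc(OC)c1OC`, 7340 nM
Compound 2, `COc1cc(/C=C2\CN(C)C/C(=C\c3ccc(Cl)cc3)C2=O)cc(OC)c1OC`, 8250 nM
Compound 3, `CN1C/C(=C\c2ccc(F)cc2)C(=O)/C(=C/c2ccc(C#N)cc2)C1`, 6140 nM

In a functional assay on HepG2 cells (Homo sapiens) for cytotoxicity, read by MTT assay, with a stated time of 24 h (a higher number here means a weaker inhibitor, a lower number a stronger inhibitor), compound 1 gives 7340 nM and compound 2 gives 8250 nM. The change between them, (chloro in place of fluoro on an aromatic carbon), produced a 1.1-fold higher number from compound 1 to compound 2 (0.05 log units; within the scatter). Compound 3 gives 6140 nM in this assay; its values against compound 1 and compound 2 lie within the scatter, and the difference between the two cores is not broken down here. Compound 4, `CN1C/C(=C\c2ccc(Cl)cc2)C(=O)/C(=C/c2ccc(C#N)cc2)C1`, carries the same change, (chloro in place of fluoro on an aromatic carbon), on the core of compound 3. Since this change gave a 1.1-fold higher number from compound 1 to compound 2 (0.05 log units; within the scatter), the expected step is a 1.1-fold higher number from compound 3 to compound 4 (0.04 log units; within the scatter), and compound 4 is estimated to give 6800 nM in this assay, between 3400 nM and 13600 nM.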

Compound 4, half-maximal inhibitory concentration: 5950 nM
The estimate for compound 4 lay 1.1-fold (0.06 log units) above the measured number; measured number inside the range.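

In this assay, exchanging 4-fluorophenyl for 4-chlorophenyl on the core of compound 3 gave a 1.0-fold lower number from compound 3 to compound 4 (0.01 log units; within the scatter). Set beside the earlier step, the change looks the same on both cores: the same change on two cores in this assay, a 1.1-fold higher number (0.05 log units; within the scatter) from compound 1 to compound 2 and a 1.0-fold lower number (0.01 log units; within the scatter) from compound 3 to compound 4, 1.2-fold (0.06 log units) apart, within the scatter of two such steps. This shows that on these two cores the change left the number within the scatter, but it does not show that a larger effect would carry over, and two cores say nothing about the rest of the series.

The compounds shown leave open what an amine or a methoxy group would do at this place in this assay. Also open, on these data alone, is whether the step would hold with a carboxylic acid in place of the nitrile of compound 3.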